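The source may hold more compounds than are shown below. What is called first, only, known or untested is meant among the compounds shown, and "the series" means these compounds.

In a functional assay on PC-6 cells (Homo sapiens) for antiproliferative activity (on this read-out higher numbers stand for weaker inhibition and lower numbers for stronger inhibition), compound 1 `CC(C)c1cc2c(N/N=C\c3ccccn3)ncnc2s1` gives 0.003 ug/mL, while compound 2 `CC(C)c1cc2c(N/N=C\c3cccnc3)ncnc2s1` gives 0.889 ug/mL, so that exchanging pyridin-2-yl for pyridin-3-yl on the carbon with a double bond to nitrogen brings a 300-fold higher number from compound 1 to compound 2 (2.47 log units; beyond the scatter). Compound 3 `CC(C)c1cc2c(N/N=C\c3ccncc3)ncnc2s1` is reported in this assay only as a limit, > 10 ug/mL, and not as a number. It therefore sits at the limit of > 10 ug/mL in this assay, at which 1 of the 3 values shown sits, the weakest position among the three measured compounds. The steps that lead to it are an at least 3300-fold higher number from compound 1 to compound 3 (3.52 log units; beyond the scatter) and an at least 11-fold higher number from compound 2 to compound 3 (1.05 log units; beyond the scatter), both large and both in the direction of weaker inhibition.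

Compound 4 `CC(C)c1cc2c(N/N=C\c3ccccc3)ncnc2s1` differs from compound 3 by phenyl in place of pyridin-4-yl on a carbon with a double bond to nitrogen. All three measured steps show that moving the ring nitrogen around the six-membered ring changes the read-out strongly, and none of them is within the scatter. Removing the ring nitrogen altogether has no measured parallel here, and the measured series gives no reason to expect a return toward the number of compound 1. Compound 4 is therefore estimated to stay near the weak end of this assay, at 5 ug/mL, with a range from 0.6 ug/mL to 40 ug/mL. That estimate corresponds to an expected step of an at least 2.0-fold lower number from compound 3 to compound 4 (0.30 log units; that floor lies within the scatter), and it may again be reported only as a limit.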

Compound 4, half-maximal inhibitory concentration: 0.651 ug/mL
The estimate for compound 4 lay 7.7-fold (0.89 log units) above the measured number; the measured number falls inside the stated range.
By their numbers in this assay, from the lowest: compound 1; then compounds 4 and 2 (each within the scatter of the next). At a limit, above all of these: compound 3.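

Removing the ring nitrogen altogether does not keep the compound at the weak end of this assay: the change brings an at least 15-fold lower number from compound 3 to compound 4 (1.18 log units; beyond the scatter), whereas a 1.4-fold lower number from compound 2 to compound 4 (0.14 log units; within the scatter), so phenyl and pyridin-3-yl cannot be told apart on this read-out. Phenyl also gives a reference that the pyridine isomers alone could not supply, since a 220-fold higher number from compound 1 to compound 4 (2.34 log units; beyond the scatter), which sets pyridin-2-yl clearly on the stronger side of the ring without nitrogen, pyridin-4-yl on the weaker side and pyridin-3-yl level with it, so the ring nitrogen counts for these four compounds only through where it stands. The reference to compound 3 still rests on a limit and not on a number, so the true size of that step stays unknown: the limit of > 10 ug/mL in this assay, at which 1 of the 4 values shown sits.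

Going by these compounds, what remains open is whether the number of compound 1 survives a methyl group or a chlorine on the pyridin-2-yl ring. On these data alone, it is equally open whether a thiazol-2-yl or imidazol-2-yl ring on the carbon with a double bond to nitrogen would behave like pyridin-2-yl or like phenyl.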